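The source may report more compounds than this note shows. Statements on the series, on what has been measured and on what is new or still open speak of the compounds shown alone.

Measured compounds:
- compound 1 `CCc1cnc(N2CCC(CCCNc3ccc4c(c3)C(=O)CC4)CC2)nc1`: 110%
- compound 2 `CC(C)c1nc(N2CCC(CCCNc3ccc4c(c3)OCC4=O)CC2)no1`: "not determined" (no result reported)
- compound 3 `CC(C)c1nsc(N2CCC(CCCNc3ccc4c(c3)OCC4=O)CC2)n1`: 93%

The measurements come from a functional assay on CHO-K1 cells for agonist activity at Glucose-dependent insulinotropic receptor (Mus musculus), read by HTRF and cAMP accumulation, with a stated time of 30 min; a higher number here means a larger maximal response, a lower number a smaller maximal response. In this assay compound 1 gives 110%, the highest of the two numbers available. Compound 3 gives 93% in this assay, a number that lies lower by more than the usual scatter. Compound 2 has no number in this assay.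

Compound 4 `CC(C)c1noc(N2CCC(CCCNc3ccc4c(c3)C(=O)CC4)CC2)n1` has not yet been measured. It keeps the core of compound 1 and differs from it in one place: 3-isopropyl-1,2,4-oxadiazol-5-yl in place of 5-ethylpyrimidin-2-yl on an amine nitrogen in a ring. For the measured compounds named here, the incoming group is the same kind of five-membered ring with three hetero atoms that compound 3 carries, although compound 3 also has a different core, so no clean step for this change exists among the measured compounds.

The change is expected to leave the maximal response broadly intact, with the step of a number 10 percentage points lower from compound 1 to compound 4 (within the scatter) from compound 1 to compound 4 estimated as a small decrease, at the edge of the scatter. Compound 4 is therefore expected to give about 100% in this assay, within a range from 80% to 115%.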

Compound 4, largest response reached (Emax), in percent of the reference or control that the assay uses: 113%
Compound 4: middle estimate off by 13 percentage points, on the low side; the range from low to high includes it.
By their numbers in this assay, from the lowest: compound 3; then compounds 1 and 4 (each within the scatter of the next).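

In this assay, placing 3-isopropyl-1,2,4-oxadiazol-5-yl in place of 5-ethylpyrimidin-2-yl on the amine nitrogen in a ring gives a number 3 percentage points higher from compound 1 to compound 4 (within the scatter), so the two groups cannot be told apart by this read-out. For the compounds shown here, this is the first direct comparison at this position on a shared core: a five-membered aromatic ring with 3 hetero atoms can stand in for a six-membered aromatic ring with 2 hetero atoms while the maximal response holds. No measurement shown here explains this tolerance.

A single pair cannot show whether the same exchange would hold on another core. Also open, going by these compounds, is whether a cyclopropyl group in place of the isopropyl, or a tert-butyl carbamate in place of the whole ring, would keep the response in this assay.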